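Three Aromatic Groups, One Level of Inhibition

The source may hold more compounds than are shown below. What is called first, only, known or untested is meant among the compounds shown, and "the series" means these compounds.

- compound 1 `Cc1ccc(/C=C/C(=O)c2cccc(NC(=O)c3cc(-c4ccncc4)n[nH]3)c2)cc1`: 64600 nM
- compound 2 `O=C(/C=C/c1ccc(F)cc1)c1cccc(NC(=O)c2cc(-c3ccncc3)n[nH]2)c1`: 58700 nM
- compound 3 `COc1cc(/C=C/C(=O)c2cccc(NC(=O)c3cc(-c4ccncc4)n[nH]3)c2)cc(OC)c1OC`: 52900 nM

These values come from a functional assay, read by spectrophotometry, tested at 100 uM; a lower number here means a stronger inhibitor, a higher number a weaker inhibitor. There, compound 3 gives 52900 nM, which lies within the scatter of the values for both other compounds. The next compound, compound 4 `CC(C)c1ccc(/C=C/C(=O)c2cccc(NC(=O)c3cc(-c4ccncc4)n[nH]3)c2)cc1`, keeps the shared core and changes only the aromatic group: 4-isopropylphenyl in place of 3,4,5-trimethoxyphenyl on a double-bonded chain carbon bound to a double-bonded chain carbon.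

For the measured compounds named here, no measured compound carries the 4-isopropylphenyl group, so the expectation rests on the three steps among its neighbours. These compounds differ only at this same place. The step of a 1.2-fold lower number from compound 1 to compound 3 (0.09 log units; within the scatter) is the closest guide, and the other two steps are a 1.1-fold lower number from compound 2 to compound 3 (0.05 log units; within the scatter) and a 1.1-fold lower number from compound 1 to compound 2 (0.04 log units; within the scatter). Going by the values given here, all three are small, and none of the measured compounds goes against this flat picture. It covers only these three compounds, however, and the new group has not been tested.

In this assay, no step beyond the scatter is therefore expected. The expected step is a 1.1-fold higher number from compound 3 to compound 4 (0.05 log units; within the scatter). For compound 4 the estimated value is 60000 nM, with an expected range from 38000 nM to 95000 nM.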

Compound 4, half-maximal inhibitory concentration: 60200 nM
For compound 4 the middle estimate is 1.0-fold (0.00 log units) below the measured one; low and high end bracket the measured number.
By their numbers in this assay, from the lowest: compounds 3, 2, 4 and 1 (each within the scatter of the next).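

In this assay, 4-isopropylphenyl in place of 3,4,5-trimethoxyphenyl gives a 1.1-fold higher number from compound 3 to compound 4 (0.06 log units; within the scatter), so on this double-bonded chain carbon, going from a group with 3 oxygen atoms, 3 hydrogen-bond acceptors and 12 heavy atoms to one with no oxygen, 0 hydrogen-bond acceptors and 9 heavy atoms leaves the number within the scatter. The isopropyl group also fits the level set by the smaller groups on the aromatic carbon: in place of fluoro it gives a 1.0-fold higher number from compound 2 to compound 4 (0.01 log units; within the scatter), and in place of methyl it gives a 1.1-fold lower number from compound 1 to compound 4 (0.03 log units; within the scatter), so all four compounds now lie within the scatter of one another and none goes against the flat picture. No measurement shown gives a reason for this flatness.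

The compounds shown leave open whether the level would hold with a charged or hydrogen-bond-donating group on the aromatic ring, such as an amine or a carboxylic acid. They also do not tell whether replacing the phenyl ring at this place with a longer chain, or altering the shared core, would produce a step beyond the scatter.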